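Selenocyanate carbamates: methyl in place of methoxy

The source may hold more compounds than are shown below. What is called first, only, known or untested is meant among the compounds shown, and "the series" means these compounds.

Measured so far:
compound 1 `COc1ccc(OC(=O)Nc2ccc([Se]C#N)cc2)cc1`: 13600 nM
compound 2 `CC(C)COC(=O)Nc1ccc([Se][Se]c2ccc(NC(=O)OCC(C)C)cc2)cc1`: 19900 nM

In a functional assay on HT-29 cells (Homo sapiens) for cytotoxicity, read by MTT assay, with a stated time of 72 h (on this read-out lower numbers stand for stronger inhibition of growth and higher numbers for weaker inhibition of growth), compound 1 gives 13600 nM, the lower of the two numbers in hand. Compound 2 gives 19900 nM in this assay; the two values lie within the scatter of each other, so no order between compound 1 and compound 2 can be read from them. Among the compounds with values here, compound 2 differs from compound 1 in more than one place, and no single step between the two is computed.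

Compound 3 `Cc1ccc(OC(=O)Nc2ccc([Se]C#N)cc2)cc1` has not yet been measured in this assay. It departs from compound 1 by methyl in place of methoxy on an aromatic carbon, while the rest of the structure is kept. Within the data shown here, no measured pair isolates a change of this kind, so the expectation for compound 3 rests on compound 1 alone. A step of a 1.0-fold higher number from compound 1 to compound 3 (0.01 log units; within the scatter) is expected, that is none beyond the scatter. For compound 3 the estimate in this assay is 14000 nM, with a range from 6000 nM to 35000 nM.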

Compound 3, concentration for 50% growth inhibition: 8800 nM
Beside the measured number, compound 3's estimate is 1.6-fold (0.20 log units) above it, within the range that was stated.
By their numbers in this assay, from the lowest: compounds 3, 1 and 2 (each within the scatter of the next, the first and the last beyond it).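

In this assay, methyl in place of methoxy on an aromatic carbon, para to a large group, gives a 1.5-fold lower number from compound 1 to compound 3 (0.19 log units; within the scatter). Within the data shown here, this is the first pair that differs in one place, and it shows that at this position the methoxy, with its oxygen and its hydrogen-bond acceptor, can give way to methyl with no difference beyond the scatter, so no order can be set between the two compounds. No measurement on hand bears on this result, and the finding rests on this single pair alone.

The compounds shown leave open whether any group at this aromatic carbon moves the number beyond the scatter, since only methoxy and methyl are covered here, and an amine, a carboxylic acid or a longer chain such as butoxy could read differently from either. They also leave open whether the same exchange of methoxy for methyl would read alike on a different cell line or with a group other than the selenocyanate on the far ring of the carbamate.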